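A morpholine in place of the amino group of compound 1

The source may hold more compounds than are shown below. What is called first, only, known or untested is meant among the compounds shown, and "the series" means these compounds.

compound 1 `CC1(C)C=C(n2ccccc2=O)c2cc(S(N)(=O)=O)ccc2O1`: 69.2 nM
compound 2 `CC1(C)C=C(n2ccccc2=O)c2cc(S(=O)(=O)Nc3ccccc3)ccc2O1`: 3.09 nM; 2 nM (2 entries)
compound 3 `COc1ccc(NS(=O)(=O)c2ccc3c(c2)C(n2ccccc2=O)=CC(C)(C)O3)cc1`: 117 nM

In a functional assay with Rattus norvegicus as the target (a lower number here means that less compound is needed, a higher number that more compound is needed for the effect), compound 1 gives 69.2 nM, the lowest of the two single numbers shown. Compound 3 is its nearest neighbour, with a 1.7-fold higher number from compound 1 to compound 3 (0.23 log units; within the scatter). For compound 2 the record holds (the several entries of compound 2 in this assay, 3.09 nM; 2 nM (2 entries)), several numbers rather than one.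

Compound 4 `CC1(C)C=C(n2ccccc2=O)c2cc(S(=O)(=O)N3CCOCC3)ccc2O1` differs from compound 1 in one place: morpholin-4-yl in place of amino on a sulfonyl sulfur. Among the measured compounds shown here, the only measured step that touches the sulfonamide, a 1.7-fold higher number from compound 1 to compound 3 (0.23 log units; within the scatter), added an aromatic group on the nitrogen and stayed within the scatter, while the phenyl of compound 2 sits well lower. For the measured compounds named here, no measured compound carries a cyclic amine on the sulfonyl sulfur, so the new group is untested here, and no step beyond the scatter is expected from it. Compound 4 is therefore estimated at 80 nM, between 20 nM and 320 nM. That estimate amounts to an expected 1.2-fold higher number from compound 1 to compound 4 (0.06 log units; within the scatter).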

Compound 4, half-maximal effective concentration: 85.1 nM
For compound 4 the middle estimate is 1.1-fold (0.03 log units) below the measured one, and the stated range covers the measured number.
By their numbers in this assay, from the lowest: compounds 1, 4 and 3 (each within the scatter of the next).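

In this assay, the first cyclic amine on the sulfonyl sulfur changes little, with a 1.2-fold higher number from compound 1 to compound 4 (0.09 log units; within the scatter) and a 1.4-fold lower number from compound 3 to compound 4 (0.14 log units; within the scatter). Morpholin-4-yl brings no hydrogen-bond donor to this position, yet compound 4 stays level with compound 1 and compound 3, so a donor here is not required to hold this level.

Compound 2 still stands apart from these three, and the compounds shown do not tell what sets it apart: the several entries of compound 2 in this assay, 3.09 nM; 2 nM (2 entries). On these data alone, whether a piperidine or a piperazine on the sulfonyl sulfur would stay with compound 4 or come closer to compound 2 remains open.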